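Thiophene isomers on the shared core: compound 3 to compound 4

The source may hold more compounds than are shown below. What is called first, only, known or untested is meant among the compounds shown, and "the series" means these compounds.

Compound 1, `Nc1nc2c(c(-c3ccccc3)cn2[C@@H]2O[C@H](CO)[C@@H](O)[C@H]2O)c(=O)[nH]1`: in a functional assay on CEM-DNR-bulk cells (Homo sapiens), read by MTT assay, with a stated time of 72 h (a higher number here means a weaker inhibitor, a lower number a stronger inhibitor), compound 1 gives > 20000 nM, a limit of the assay.
Compound 2, `O=c1[nH]cnc2c1c(-c1cccs1)cn2[C@@H]1O[C@H](CO)[C@@H](O)[C@H]1O`: in this assay compound 2 gives > 20000 nM, also a limit.
Compound 3, `Nc1nc2c(c(-c3ccsc3)cn2[C@@H]2O[C@H](CO)[C@@H](O)[C@H]2O)c(=O)[nH]1`: in this assay compound 3 gives > 20000 nM, again a limit.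

Compound 3 therefore stands only at a limit in this assay, and the whole measured set sits there (the limit of > 20000 nM in this assay, at which 3 of the 3 values shown sit). Within the data shown here, the single step between measured neighbours, a step that the two limits leave unreadable from compound 1 to compound 3, is unreadable, with both ends limits. Compound 4, `Nc1nc2c(c(-c3cccs3)cn2[C@@H]2O[C@H](CO)[C@@H](O)[C@H]2O)c(=O)[nH]1`, differs from compound 3 as thiophen-2-yl in place of thiophen-3-yl on an aromatic carbon. Compound 2 carries the same thiophen-2-yl group and sits at a limit. Among the measured compounds shown here, no measured step bears on the change, so no shift beyond the scatter is expected; the expected step is a step that the limit leaves unreadable from compound 3 to compound 4. Compound 4 is expected to give 30000 nM in this assay, within 15000 nM to 80000 nM, most probably reported only as a limit.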

Compound 4, half-maximal inhibitory concentration: > 20000 nM
Compound 4 ended at the assay's limit; the forecaster's own chance of this, stated with the estimate: 85%; the middle value lies beyond the limit too.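

No step from compound 4 to compound 1, compound 2 or compound 3 can be read in this assay, since both ends of each are limits: the limit of > 20000 nM in this assay, at which 4 of the 4 values shown sit.

The compounds shown leave open whether phenyl, thiophen-2-yl, thiophen-3-yl or amino changes potency on the shared core.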